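The source may hold more compounds than are shown below. What is called first, only, known or untested is meant among the compounds shown, and "the series" means these compounds.

Working notes on the series.

Among the measured compounds shown here, compound 1 `O=C(CCSc1nnc(-c2ccncc2)s1)NCc1ccccc1` is the one member with a full number: in an ADME assay on BHK-21 cells (Mesocricetus auratus) for cytotoxicity, with a stated time of 3 days (a higher number here means that more compound is tolerated, a lower number that less compound is tolerated), compound 1 gives 18700 nM. Compound 2 `CC(CSc1nnc(-c2ccncc2)s1)C(=O)NCc1ccccc1` carries a methyl in place of hydrogen on a saturated chain carbon bound to a carbonyl carbon and a saturated chain carbon. In this assay compound 2 gives > 50000 nM, which is a limit of the assay and not a number. The step reads an at least 2.6-fold higher number from compound 1 to compound 2 (0.42 log units; beyond the scatter), its size bounded by the limit of > 50000 nM in this assay, at which 1 of the 2 values shown sits.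

Compound 3 `O=C(CCSc1nnc(-c2ccncc2)s1)NCc1ccc(Cl)cc1` differs from compound 1 on the benzyl side: chloro in place of hydrogen on an aromatic carbon. For the measured compounds named here, no measured step touches the aromatic ring; the one step known, from compound 1 to compound 2, sits on the chain and so says nothing direct about a chloro in place of hydrogen on an aromatic carbon. Going by the values given here, with no bearing step, the expectation in this assay is a change no larger than the scatter, in either direction. The estimated step is therefore a 1.1-fold lower number from compound 1 to compound 3 (0.04 log units; within the scatter). Compound 3 is estimated at 17000 nM, with the expected range running from 7000 nM to 45000 nM.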

Compound 3, half-maximal cytotoxic concentration: 21500 nM
The estimate for compound 3 lay 1.3-fold (0.10 log units) below the measured number; the range from low to high includes it.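

In this assay, among the compounds shown here, the step is a 1.1-fold higher number from compound 1 to compound 3 (0.06 log units; within the scatter), which gives the first reading on the aromatic ring. For the compounds shown here, at this place, on an aromatic carbon para to a large group, the change from benzyl to 4-chlorobenzyl moves the number by no more than the scatter, whereas the one earlier step, on the saturated chain, lies beyond it. The chain step still has no exact size, as compound 2 stands at a limit and not at a number: the limit of > 50000 nM in this assay, at which 1 of the 3 values shown sits.

On these data alone, one chloro says little about the ring position as a whole, and it remains open whether a group of another kind in the same place, such as an amine, a carboxylic acid or a methoxy, would also stay within the scatter of compound 1. Also open are chloro at other carbons of the ring and a longer chain between the sulfur and the carbonyl, and no compound shown carries the ring chloro and the chain methyl together.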